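The source may hold more compounds than are shown below. What is called first, only, known or untested is meant among the compounds shown, and "the series" means these compounds.

The three measured compounds share one core and differ only in the aryl group attached to the carbonyl carbon. Compound 1 `COc1ccc(/C=C/c2cc(OC)cc(OC)c2/C=C/C(=O)c2ccc(C(F)(F)F)cc2)cc1` gives 7.8 ug/mL in a functional assay on A549 cells (Homo sapiens) for antiproliferative activity, read by MTT assay, with a stated time of 48 h; on this read-out lower numbers stand for stronger inhibition and higher numbers for weaker inhibition. Compound 2 `COc1ccc(/C=C/c2cc(OC)cc(OC)c2/C=C/C(=O)c2cccc(Cl)c2)cc1` gives 5.6 ug/mL in this assay, and compound 3 `COc1ccc(/C=C/c2cc(OC)cc(OC)c2/C=C/C(=O)c2ccc(OC)cc2)cc1` gives 4.5 ug/mL in this assay. The steps of a 1.4-fold lower number from compound 1 to compound 2 (0.14 log units; within the scatter), a 1.7-fold lower number from compound 1 to compound 3 (0.24 log units; within the scatter) and a 1.2-fold lower number from compound 2 to compound 3 (0.09 log units; within the scatter) all fall within the scatter, so compound 3, although it carries the lowest number of the three, cannot be set apart from compound 2 or from compound 1 on these data.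

Compound 4 `COc1ccc(/C=C/c2cc(OC)cc(OC)c2/C=C/C(=O)c2ccc(C)cc2C)cc1` has not yet been measured in this assay. It differs from compound 3 by 2,4-dimethylphenyl in place of 4-methoxyphenyl on a carbonyl carbon. Within the data shown here, two measured steps bear on this same position: a 1.2-fold lower number from compound 2 to compound 3 (0.09 log units; within the scatter) and a 1.7-fold lower number from compound 1 to compound 3 (0.24 log units; within the scatter), both within the scatter. Neither shows an exchange of the aryl group on the carbonyl carbon moving the number beyond the scatter, and on that basis no step beyond the scatter is expected for a 1.2-fold higher number from compound 3 to compound 4 (0.09 log units; within the scatter). Compound 4 is therefore estimated at 5.5 ug/mL in this assay, with a range from 2.5 ug/mL to 12 ug/mL.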

Compound 4, half-maximal inhibitory concentration: 0.3 ug/mL
Compound 4: middle estimate off by 18-fold (1.26 log units), on the high side, and the stated range ends above it.
By their numbers in this assay, from the lowest: compound 4; then compounds 3, 2 and 1 (each within the scatter of the next).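

In this assay, exchanging the aryl group on the carbonyl carbon can move the number beyond the scatter: 2,4-dimethylphenyl in place of 4-methoxyphenyl gives a 15-fold lower number from compound 3 to compound 4 (1.18 log units; beyond the scatter) and, set against the other two aryl groups, gives a 19-fold lower number from compound 2 to compound 4 (1.27 log units; beyond the scatter) and a 26-fold lower number from compound 1 to compound 4 (1.41 log units; beyond the scatter) in this series. The earlier compounds shown here showed no such movement, as 4-(trifluoromethyl)phenyl, 3-chlorophenyl and 4-methoxyphenyl stayed within the scatter of one another, so this position proves able to separate compounds, and compound 4 is the only one of the four set apart from all the others. Nothing shown here accounts for why this one exchange has so large a step.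

The compounds shown leave open whether both methyl groups of 2,4-dimethylphenyl are needed, or whether a phenyl group carrying a single methyl would give a number close to that of compound 4. They also leave open how the number would respond to longer chains such as ethyl in place of those methyl groups, or to an aryl group carrying an amine or a carboxylic acid.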